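The source may report more compounds than this note shows. Statements on the series, on what has been measured and on what is new or still open speak of the compounds shown alone.

In an ADME assay on cells (Homo sapiens) for cytotoxicity, read by resazurin assay, with a stated time of 5 days (on this read-out higher numbers stand for lower toxicity in this test and lower numbers for higher toxicity in this test), compound 3 `COc1ccc(-c2nc(CC(O)c3cccc(Cl)c3)nc3ccsc23)cn1` gives 31000 nM. Compound 1 `COc1ccc(-c2nc(CC(=O)c3cccc(Cl)c3)nc3ccsc23)cn1` gives 30000 nM, which lies within the scatter of the value for compound 3. Compound 2 `COc1ccc(-c2nc(CSc3ccc(C(F)(F)F)cn3)nc3ccsc23)cn1` gives > 50000 nM, which is a limit and not a number.

Compound 4 `COc1ccc(-c2nc(C[S+]([O-])c3cccc(Cl)c3)nc3ccsc23)cn1` differs from compound 3 by a single change on a saturated chain carbon bound to an aromatic carbon: a group of 9 heavy atoms (6 carbon, 1 oxygen, 1 sulfur, 1 chlorine; one six-membered aromatic ring of carbon only) in place of a group of 9 heavy atoms (7 carbon, 1 oxygen, 1 chlorine; one six-membered aromatic ring of carbon only), on a saturated chain carbon bound to an aromatic carbon. Among the measured compounds shown here, one measured step bears on this place, the exchange of (3-chlorophenyl)carbonyl for (3-chlorophenyl)(hydroxy)methyl: a 1.0-fold higher number from compound 1 to compound 3 (0.01 log units; within the scatter). That step stays within the scatter, but it does not involve the group that enters in compound 4, so it is only indirect support.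

For the measured compounds named here, no step beyond the scatter is expected in this assay because a 1.0-fold higher number from compound 1 to compound 3 (0.01 log units; within the scatter) is the only measured step at this place. The expected size of the change is a 1.1-fold higher number from compound 3 to compound 4 (0.03 log units; within the scatter). The estimate for compound 4 is 33000 nM, with an expected range from 15000 nM to 50000 nM.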

Compound 4, half-maximal cytotoxic concentration: > 50000 nM
Compound 4 gave a limit, no number; the forecaster's own chance of this, stated with the estimate: 25%; middle value at least 1.5-fold (0.18 log units) from the limit.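

In this assay, among the compounds shown here, the sulfur-bearing group of compound 4 is the first exchange at this place to leave the read-out at a limit: it gives an at least 1.6-fold higher number from compound 3 to compound 4 (0.20 log units; that floor lies within the scatter), and the exchange starting from the carbonyl gives an at least 1.6-fold higher number from compound 1 to compound 4 (0.22 log units; that floor lies within the scatter). Both steps are floors that lie within the scatter, so they show no measured rise, but a sulfur atom in this group brings no sign of higher toxicity in this test on a saturated chain carbon bound to an aromatic carbon. The top of the read-out now caps what this place can show: the limit of > 50000 nM in this assay, at which 2 of the 4 values shown sit.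

On these data alone, how far compound 4 truly stands from compound 3 stays open. Also open, as far as these compounds go, is how an amine, a carboxylic acid or a longer chain at this place would read out.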